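The compounds below may be only part of what the source reports. "The series", "measured", "known", "first", "only" and "open" are said of these compounds alone.

Working notes on the series. In a functional assay on ECa-109 cells (Homo sapiens) for antiproliferative activity, with a stated time of 72 h (on this read-out lower numbers stand for stronger inhibition and higher numbers for weaker inhibition), compound 1 (`COc1cc(OC)c(C(=O)/C=C/c2ccccc2Cl)c(O)c1CN1CCCC1`) gives 6900 nM and compound 3 (`COc1cc(OC)c(C(=O)/C=C/c2ccccc2Cl)c(O)c1CN(C)C`) gives 2600 nM. Compound 2 (`COc1cc(O)c2c(=O)cc(-c3ccccc3Cl)oc2c1CN1CCCCC1`) gives 21500 nM, the highest number of the three and therefore the weakest inhibition in this small set. Its core differs from the core of compound 1, and it stands apart from both of the other measured compounds.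

Compound 4 (`COc1cc(OC)c2c(=O)cc(-c3ccccc3Cl)oc2c1CN1CCCCC1`) is the next entry. Its change is methyl in place of hydrogen on an oxygen on an aromatic ring, which is methyl in place of hydrogen on an oxygen on an aromatic ring, or hydroxy to methoxy.

For the measured compounds named here, the only measured single-place step is a 2.7-fold lower number from compound 1 to compound 3 (0.42 log units; beyond the scatter), for dimethylamino in place of pyrrolidin-1-yl on a saturated chain carbon bound to an aromatic carbon. That step lies at a different place and on a different core, so it gives only a rough size for one change in this series and no direction for this one. Going by the values given here, no measured pair tests hydroxy to methoxy. No shift beyond the scatter is therefore expected in this assay, though the uncertainty is wide.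

The expected step is a 1.2-fold lower number from compound 2 to compound 4 (0.08 log units; within the scatter). The estimate for compound 4 is 18000 nM, with an expected range of 6000 nM to 50000 nM.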

Compound 4, half-maximal inhibitory concentration: 23700 nM
For compound 4 the middle estimate is 1.3-fold (0.12 log units) below the measured one, and the stated range covers the measured number.
By their numbers in this assay, from the lowest: compound 3; then compound 1; then compounds 2 and 4 (each within the scatter of the next).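

For the compounds shown here, the first measured pair for hydroxy to methoxy, on an oxygen on an aromatic ring, shows no shift beyond the scatter in this assay: a 1.1-fold higher number from compound 2 to compound 4 (0.04 log units; within the scatter). On this core, therefore, methyl in place of hydrogen at this position leaves the read-out unresolved from that of the hydroxy compound, so the hydrogen on that oxygen is not needed to retain this level of activity, weak as it is in this set. Nothing available bears on why the change has so little effect on the read-out.

Going by these compounds, this is one pair on one core, so it is open whether a larger group on the same oxygen, such as ethoxy, benzyloxy or a longer chain ending in a carboxylic acid, would also stay within the scatter, and whether hydroxy to methoxy would read the same on the core of compound 1. Also open, on these data alone, is whether dimethylamino on the core of compound 4 would repeat the change seen on another core, where the step is a 2.7-fold lower number from compound 1 to compound 3 (0.42 log units; beyond the scatter).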